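The compounds below may be only part of what the source reports. "The series", "measured", "known", "first", "only" and "open" are said of these compounds alone.

Measured in a functional assay on COLO 205 cells (Homo sapiens) for antiproliferative activity, read by MTT assay, with a stated time of 68 h; a higher number here means a weaker inhibitor, a lower number a stronger inhibitor:
compound 1 `O=S(=O)(Nc1ccc(F)c(C#Cc2cnc3[nH]ccc3c2)c1F)c1cccnc1`: 1170 nM
compound 2 `COc1n[nH]c2ncc(C#Cc3c(F)ccc(NS(=O)(=O)c4cccnc4)c3F)cc12`: 89 nM

Compound 2, at 89 nM, has the lower of the two numbers, and the gap to compound 1 lies beyond the scatter of repeated measurements. Among the compounds with values here, these two compounds differ in more than one place, so the data contain no single-change step to gauge the next one by. Compound 3 `Cc1n[nH]c2ncc(C#Cc3c(F)ccc(NS(=O)(=O)c4cccnc4)c3F)cc12` departs from compound 2 in one group only: methyl in place of methoxy on an aromatic carbon. That carbon belongs to a five-membered aromatic ring with 2 nitrogen, part of a fused or bridged system of two rings. With nothing measured on this exchange, only a modest move is expected in this assay, most likely a slight rise in the number, and it may well stay within the scatter. The estimate corresponds to an expected 1.7-fold higher number from compound 2 to compound 3 (0.23 log units; within the scatter). Compound 3 is estimated at 150 nM, with an expected range of 40 nM to 600 nM.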

Compound 3, half-maximal inhibitory concentration: 148 nM
The estimate for compound 3 lay 1.0-fold (0.01 log units) above the measured number; low and high end bracket the measured number.
By their numbers in this assay, from the lowest: compounds 2 and 3 (each within the scatter of the next); then compound 1.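

In this assay, the exchange of methoxy for methyl on this aromatic carbon gives a 1.7-fold higher number from compound 2 to compound 3 (0.22 log units; within the scatter), so this carbon of the five-membered aromatic ring carries either group with no difference that can be told from the scatter, even though a heavy atom and a hydrogen-bond acceptor leave with the methoxy. The change on the triple-bonded carbon can now be read as a single step, and it gives a 7.9-fold lower number from compound 1 to compound 3 (0.90 log units; beyond the scatter), a gap beyond the scatter that the earlier pair, differing in more than one place, could not provide. Nothing at hand accounts for either step.

Within the data shown here, the single step between compound 1 and compound 3 swaps the whole group on the triple-bonded carbon, so it leaves apart neither the contribution of the added ring nitrogen nor that of the methyl. From the compounds shown here alone, how this aromatic carbon would respond to a plain hydrogen, an amine, a chlorine or a longer chain such as ethyl remains open.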